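Extending the chain of compound 1

The source may hold more compounds than are shown below. What is called first, only, known or untested is meant among the compounds shown, and "the series" means these compounds.

Values in a functional assay on MDA-MB-231 cells (Homo sapiens) for inhibition, read by MTT assay, with a stated time of 72 h; on this read-out higher numbers stand for weaker inhibition and lower numbers for stronger inhibition:
compound 1 `Nc1ncnc2c1c(-c1cnc3[nH]ccc3c1)nn2CC(=O)NO`: > 150000 nM
compound 2 `Nc1nc2cc(-c3nn(CCCCCC(=O)NO)c4ncnc(N)c34)ccc2o1`: 19000 nM
compound 3 `Nc1nc2cc(-c3nn(CC(=O)NO)c4ncnc(N)c34)ccc2o1`: 6310 nM

Compound 1 offers no number to start from, only a limit: the limit of > 150000 nM in this assay, at which 1 of the 3 values shown sits. The compound still to be measured is compound 4 `Nc1ncnc2c1c(-c1cnc3[nH]ccc3c1)nn2CCCC(=O)NO`. It carries 2-(hydroxycarbamoyl)ethyl in place of hydroxycarbamoyl on a saturated chain carbon bound to an aromatic nitrogen, while the core of compound 1 stays the same: 2-(hydroxycarbamoyl)ethyl in place of hydroxycarbamoyl on a saturated chain carbon bound to an aromatic nitrogen.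

Within the data shown here, only one measured step bears on this change, and it belongs to a different core, where hydroxycarbamoyl takes the place of 4-(hydroxycarbamoyl)butyl. The expectation for compound 4 rests on that modest step, a 3.0-fold lower number from compound 2 to compound 3 (0.48 log units; beyond the scatter), read in reverse: a somewhat higher number as the chain grows. One pair settles little, and the starting point is a limit, so no step beyond the scatter is expected in this assay. Compound 4 may well return only a limit too.

The estimated change is an at least 1.1-fold lower number from compound 1 to compound 4 (0.06 log units; that floor lies within the scatter). For compound 4 the expected value is 130000 nM, with an estimated range from 25000 nM to 400000 nM.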

Compound 4, half-maximal inhibitory concentration: > 150000 nM
Compound 4 gave a limit, no number; the forecaster's own chance of this, stated with the estimate: 50%; middle value at least 1.1-fold (0.06 log units) from the limit.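

In this assay compound 4 gives > 150000 nM, which is a limit and not a number. Compound 1 also sits at a limit, so no step can be read from compound 1 to compound 4: the limit of > 150000 nM in this assay, at which 2 of the 4 values shown sit.

The compounds shown leave open whether 2-(hydroxycarbamoyl)ethyl in place of hydroxycarbamoyl changes inhibition at all on the core of compound 1.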